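The compounds below may be only part of what the source reports. "The series", "measured", "known", "first", "only" and "open" are said of these compounds alone.

Measured so far:
- compound 1, `COc1ccc(-c2cc(/C=C/C(=O)c3ccc(N)cc3)[nH]n2)cc1`: in a functional assay on ACHN cells (Homo sapiens) for cytotoxicity, read by sulforhodamine B assay, with a stated time of 48 h, tested at 0.01 uM (on this read-out higher numbers stand for a weaker effect at the one concentration tested and lower numbers for a stronger effect), compound 1 gives 103%
- compound 2, `COc1cc(-c2cc(/C=C/C(=O)c3ccc(N)cc3)[nH]n2)cc(OC)c1OC`: in this assay compound 2 gives 95%

Compound 2 holds the lowest of the two numbers in this assay. The nearest is compound 1, whose number is higher by an amount that lies within the usual scatter, so the two readings cannot be told apart and neither compound can be called the stronger. Among the measured compounds shown here, no pair of measured compounds differs in one place only, so no single-change step is available as a yardstick.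

Compound 3, `COc1ccc(-c2cc(/C=C/C(=O)c3ccc(N)cc3)[nH]n2)cc1OC`, is not yet measured. It differs from compound 2 as follows: hydrogen in place of methoxy on an aromatic carbon

Both measured readings in this assay sit at a level that means little or no effect at the one concentration used, and they agree within the scatter. On that basis the step from compound 2 to compound 3 is expected to be none beyond the scatter, a number 4 percentage points higher from compound 2 to compound 3 (within the scatter). Compound 3 is estimated at 99% in this assay, with a range from 88% to 110%.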

Compound 3, a percentage reported as activity, at one concentration (the size of the read-out at that concentration, not a potency): 93%
Beside the measured number, compound 3's estimate is 6 percentage points above it; the measured number falls inside the stated range.
By their numbers in this assay, from the lowest: compounds 3, 2 and 1 (each within the scatter of the next).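

Two single-change steps now exist on the methoxy-bearing six-membered aromatic ring of carbon only, and neither can be told from the scatter. In this assay, hydrogen in place of methoxy on the aromatic carbon ortho to a methoxy group and meta to a large group gives a number 2 percentage points lower from compound 2 to compound 3 (within the scatter) and so leaves no reading of this methoxy at the one concentration tested. Going the other way along the series, methoxy in place of hydrogen gives a number 10 percentage points lower from compound 1 to compound 3 (within the scatter) in this assay and is equally unreadable, so across these three compounds the number of methoxy groups shows no separable link to the read-out, and no measurement offers an explanation for these readings.

Among the compounds shown here, all three compounds sit at a level of little or no effect, so these steps say only that the changes do not produce activity at this single concentration, and they leave open whether the same changes would separate at a concentration where the series shows an effect. Also open, going by these compounds, is whether a different group on this aromatic carbon, such as a hydroxyl, a fluorine or an amine, would move the number beyond the scatter.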